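Chalcone oxyacetamide series: aryl variation and antiproliferative potency

This account rests on a few compounds, and the source may have more. Where it says the series, first, only, none or still open, it means among the compounds named here.

Measured compounds:
compound 1 `O=C(COc1ccc(C(=O)/C=C/c2cccc(Cl)c2)cc1)N[C@H]1CCOC1=O`, 29100 nM
compound 2 `O=C(COc1ccc(C(=O)/C=C/c2ccccc2Cl)cc1)N[C@H]1CCOC1=O`, 27100 nM
compound 3 `CC(C)(C)c1ccc(/C=C/C(=O)c2ccc(OCC(=O)N[C@H]3CCOC3=O)cc2)cc1`, 17200 nM

All three share one core and differ only in the aryl group on the double-bonded chain. Going by the values given here, in a functional assay on MGC-803 cells (Homo sapiens) for antiproliferative activity, read by MTT assay, with a stated time of 72 h (a lower number here means a stronger inhibitor, a higher number a weaker inhibitor), compound 3 gives the lowest of the three numbers, but the steps of a 1.7-fold lower number from compound 1 to compound 3 (0.23 log units; within the scatter) and a 1.6-fold lower number from compound 2 to compound 3 (0.20 log units; within the scatter) are both within the scatter, as is a 1.1-fold lower number from compound 1 to compound 2 (0.03 log units; within the scatter), so no compound can be called the most potent.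

Compound 4 `O=C(COc1ccc(C(=O)/C=C/c2ccccc2)cc1)N[C@H]1CCOC1=O` is not yet measured. It differs from compound 3 by hydrogen in place of tert-butyl on an aromatic carbon. Among the compounds with values here, no measured step removes a substituent from the aryl ring outright; the closest comparisons are the aryl swaps from compound 1 and compound 2 to compound 3, each within the scatter. On that basis no step beyond the scatter is expected in this assay for compound 4, that is a 1.5-fold higher number from compound 3 to compound 4 (0.16 log units; within the scatter) is the expected change.

The estimate for compound 4 in this assay is 25000 nM, with a range from 9000 nM to 70000 nM.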

Compound 4, half-maximal inhibitory concentration: > 64000 nM
Compound 4: only a limit was reported (the forecaster's own chance of this, stated with the estimate: 10%); middle value at least 2.5-fold (0.40 log units) from the limit.
By their numbers in this assay, from the lowest: compounds 3, 2 and 1 (each within the scatter of the next). At a limit, above all of these: compound 4.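

In this assay, compound 4, which carries a plain phenyl, is reported only as a limit and not as a number: the limit of > 64000 nM in this assay, at which 1 of the 4 values shown sits. Losing the ring substituent altogether is the first change in the series to go beyond the scatter, read as an at least 3.7-fold higher number from compound 3 to compound 4 (0.57 log units; beyond the scatter), an at least 2.3-fold higher number from compound 2 to compound 4 (0.37 log units; beyond the scatter) and an at least 2.1-fold higher number from compound 1 to compound 4 (0.34 log units; beyond the scatter). Tert-butyl and chloro could not be separated from one another in the earlier swaps, but each of the three substituted compounds now has a lower number than the plain phenyl, so having a group on this ring matters more here than which of these groups it is.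

From the compounds shown here alone, the full size of these steps stays open, as each rests on a limit. Also open, going by these compounds, is whether a methyl, a methoxy, an amine or a carboxylic acid on this ring would give numbers like those of tert-butyl and chloro.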